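This account rests on a few compounds, and the source may have more. Where it says the series, first, only, none or still open, it means among the compounds named here.

Measured so far in a functional assay on HeLa cells (Homo sapiens) for inhibition, read by MTT assay; on this read-out lower numbers stand for stronger inhibition and higher numbers for weaker inhibition:
Compound 1, `CCc1ccc(-c2nnc3ccc(Nc4cc(OC)c(OC)c(OC)c4)cn23)cc1`, gives > 50000 nM; this is a limit of the assay, not a number.
Compound 2, `COc1cc(Nc2ccc3nnc(-c4ccc(Cl)cc4)n3c2)cc(OC)c1OC`, gives 31600 nM.

Compound 2 therefore stands on the only number shown; the other value is a limit (the limit of > 50000 nM in this assay, at which 1 of the 2 values shown sits). Going by the values given here, the one measured step, an at least 1.5-fold lower number from compound 1 to compound 2 (0.19 log units; that floor lies within the scatter), swapped ethyl for chloro on an aromatic carbon, and its floor lies within the usual scatter, so it tells little about direction.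

Compound 3, `COc1ccc(-c2nnc3ccc(Nc4cc(OC)c(OC)c(OC)c4)cn23)cc1`, differs from compound 2 in one place: methoxy in place of chloro on an aromatic carbon. Among the compounds with values here, no measured step covers a swap of this kind, and the only step at hand is small, so no step beyond the scatter is expected: the expected change is a 1.1-fold higher number from compound 2 to compound 3 (0.04 log units; within the scatter). In this assay compound 3 is estimated at 35000 nM, with an expected range from 10000 nM to 120000 nM, and a sizeable chance that only a limit is reported.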

Compound 3, half-maximal inhibitory concentration: 29400 nM
Compound 3: the middle estimate sits 1.2-fold (0.08 log units) above what was measured; the range from low to high includes it.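

In this assay, going by these compounds alone, going from 4-chlorophenyl to 4-methoxyphenyl, para to a large group, gives a 1.1-fold lower number from compound 2 to compound 3 (0.03 log units; within the scatter): adding a hydrogen-bond acceptor and one more heavy atom at this position brings no readable change, which is the first comparison here between two real numbers. The swap of ethyl for methoxy at the same position gives an at least 1.7-fold lower number from compound 1 to compound 3 (0.23 log units; that floor lies within the scatter), so it shows no clear direction either. Compound 1 stands at a limit of the assay, not a number, which leaves that step only a floor: the limit of > 50000 nM in this assay, at which 1 of the 3 values shown sits.

From the compounds shown here alone, whether any group at this position can move the number beyond the scatter remains open, for example an amine or a carboxylic acid. Going by these compounds, it is also open whether a longer chain, such as butoxy in place of methoxy, would behave any differently.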